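Working notes: from ethoxy to benzyloxy

The source may hold more compounds than are shown below. What is called first, only, known or untested is meant among the compounds shown, and "the series" means these compounds.

Values so far in a functional assay on thoracic aorta (Rattus norvegicus, strain Wistar), with a stated time of 15 min; on this read-out lower numbers stand for an effect already at smaller amounts and higher numbers for an effect only at larger amounts of compound:
Compound 1 `CCOc1ccc(Cl)cc1C(C)NC(=O)N(C)S(=O)(=O)c1ccccc1` gives 10500 nM
Compound 2 `CCOc1ccc(Br)cc1C(C)NC(=O)NS(=O)(=O)c1ccccc1` gives > 300000 nM, which is a limit and not a number
Compound 3 `CCOc1ccc(Br)cc1C(C)NC(=O)N(C)S(=O)(=O)c1ccccc1` gives 19800 nM

Within the data shown here, compound 3 and compound 1 hold the only two actual numbers in this assay, and they lie within the scatter of each other: a 1.9-fold higher number from compound 1 to compound 3 (0.28 log units; within the scatter), with bromo in place of chloro. Compound 4 `CC(NC(=O)N(C)S(=O)(=O)c1ccccc1)c1cc(Br)ccc1OCc1ccccc1` is next, with phenyl in place of methyl on a saturated chain carbon bound to an oxygen on an aromatic ring, that is, ethoxy to benzyloxy (phenyl in place of methyl on a saturated chain carbon bound to an oxygen on an aromatic ring).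

Neither measured step touches that place. The large one is an at least 15-fold lower number from compound 2 to compound 3 (1.18 log units; beyond the scatter), with methyl in place of hydrogen on an amide-type nitrogen, and compound 4 keeps that methyl. The estimate therefore starts from compound 3 (19800 nM), with wide margins on both sides. No shift beyond the scatter is expected, and the expected step is a 1.0-fold higher number from compound 3 to compound 4 (0.00 log units; within the scatter) in this reading. Compound 4 is estimated at 20000 nM, with an expected range from 6000 nM to 70000 nM as the working margin.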

Compound 4, half-maximal effective concentration: 60300 nM
Compound 4: the middle estimate sits 3.0-fold (0.48 log units) below what was measured; the measured number falls inside the stated range.
By their numbers in this assay, from the lowest: compounds 1 and 3 (each within the scatter of the next); then compound 4. At a limit, above all of these: compound 2.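

Ethoxy to benzyloxy is the first change at this place, on a saturated chain carbon bound to an oxygen on an aromatic ring, and in this assay it gives a step beyond the scatter: a 3.0-fold higher number from compound 3 to compound 4 (0.48 log units; beyond the scatter). The step is modest, so the number moves with the group at this place: compound 4 gives 60300 nM. Nothing available here bears on the origin of this step.

On these data alone, with only ethoxy and benzyloxy at this place, it remains open whether the higher number goes with the aromatic ring itself or with chain length, a question that a propoxy chain or a cyclohexylmethoxy group would address. Also open, as far as these compounds go, is how benzyloxy behaves with chloro in place of bromo.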